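An ethoxycarbonyl in place of a hydrazone

A few compounds are considered here, and "the series" means these few. Any claim that something is new, unique, unknown or untested is made for them only; others in the source may bear on it.

Compound 1, `C=C[C@@](C)(/C=C/c1ccc(O)cc1)CCC=O`: in a functional assay on HepG2 cells (Homo sapiens) for cytotoxicity, with a stated time of 72 h (a lower number here means that less compound is needed, a higher number that more compound is needed for the effect), compound 1 gives > 52000 nM, a limit of the assay.
Compound 2, `C=C[C@@](C)(/C=C/c1ccc(O)cc1)CC/C=C(C)/C=N/N`: in this assay compound 2 gives > 52000 nM, also a limit of the assay.

Compound 2 therefore stands at the limit of > 52000 nM in this assay, at which 2 of the 2 values shown sit, with no number of its own. The step that the two limits leave unreadable from compound 1 to compound 2 is unreadable, as both ends are limits. Compound 3, `C=C[C@@](C)(/C=C/c1ccc(O)cc1)CC/C=C(\C)C(=O)OCC`, differs from compound 2 by a group of 5 heavy atoms (3 carbon, 2 oxygen; no ring) in place of a group of 3 heavy atoms (1 carbon, 2 nitrogen; no ring), on a double-bonded chain carbon bound to a double-bonded chain carbon and a saturated chain carbon. No readable measured step bears on this change, so no direction can be expected beyond the scatter. Compound 3 is expected to give 60000 nM, with a range from 20000 nM to 200000 nM. The step that the limit leaves unreadable from compound 2 to compound 3 is expected to be slight at most.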

Compound 3, half-maximal effective concentration: > 52000 nM
Compound 3: no number, only a limit (the forecaster's own chance of this, stated with the estimate: 75%); the middle value is on the limit's open side.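

The step from compound 2 to compound 3 cannot be read, as both ends are limits of the assay: the limit of > 52000 nM in this assay, at which 3 of the 3 values shown sit.

The compounds shown leave open whether the ethoxycarbonyl of compound 3 changes anything in this assay, as no compound here has a number of its own.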